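The source may report more compounds than this note shows. Statements on the series, on what has been measured and on what is new or still open speak of the compounds shown alone.

Compound 1 `CC(C)n1nc(N2CC(C(C)(C)O)C2)c2cnc(Nc3ccnc(-c4cnn(S(=O)(=O)C5CC5)c4)n3)cc21` carries an isopropyl group on the ring nitrogen of its shared core and in an ADME assay on microsomes from liver (Homo sapiens) for pharmacokinetics (on this read-out lower numbers stand for slow clearance and higher numbers for fast clearance), compound 1 gives 8.9 mL/min/kg. Compound 2 `CC[C@@H](C)n1nc(N2CC(C(C)(C)O)C2)c2cnc(Nc3ccnc(-c4cnn(S(=O)(=O)C5CC5)c4)n3)cc21` differs from it by a methyl in place of hydrogen on a saturated chain carbon, two bonds along the chain from an aromatic nitrogen, and in this assay compound 2 gives 9.9 mL/min/kg. The step of a 1.1-fold higher number from compound 1 to compound 2 (0.05 log units; within the scatter) leaves the two compounds within the scatter of each other, so compound 2 stands level with compound 1 on the numbers shown. Compound 3 `CC[C@H](C)n1nc(N2CC(C(C)(C)O)C2)c2cnc(Nc3ccnc(-c4cnn(S(=O)(=O)C5CC5)c4)n3)cc21` is the mirror-image partner of compound 2: the two compounds have the same atoms and bonds and differ only in configuration as drawn: 1 of 1 stereo elements differ; a stereocentre at a saturated chain carbon is drawn R in compound 2 and S in compound 3. For the measured compounds named here, no measured pair shows what a change of configuration alone does here; the only step available, from compound 1 to compound 2, added a group and was itself small. Nothing therefore points to a move beyond the scatter, and the expectation is a step of no change at the digits printed from compound 2 to compound 3 (within the scatter) in this assay. Compound 3 is accordingly estimated at 9.9 mL/min/kg, in a range from 5 mL/min/kg to 20 mL/min/kg.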

Compound 3, clearance: 3.8 mL/min/kg
Compound 3: the middle estimate sits 2.6-fold (0.42 log units) above what was measured; measured number outside the range, below it.
By their numbers in this assay, from the lowest: compound 3; then compounds 1 and 2 (each within the scatter of the next).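

In this assay this position on the ring nitrogen of the shared core responds to the direction of the substituent as well as to its size, with a 2.6-fold lower number from compound 2 to compound 3 (0.42 log units; beyond the scatter), and this gap can be assigned to the stereocentre alone because nothing else separates the pair: the fact that compounds 2 and 3 differ only in the configuration as drawn The added methyl therefore has no single reading, since with the stereocentre drawn R, in compound 2, it stays within the scatter of compound 1, whereas with the stereocentre drawn S it gives a 2.3-fold lower number from compound 1 to compound 3 (0.37 log units; beyond the scatter). Compound 3 thus has the lowest number of the three, while compound 1 and compound 2 stand level.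

The compounds shown leave open whether the advantage of the S form carries over to other groups at this stereocentre, such as a longer chain in place of the ethyl arm or a trifluoromethyl in place of the added methyl. They also leave open whether a similar gap between mirror-image partners would appear if the cyclopropyl on the sulfonyl group gave way to a simple methyl.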